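Chloro for methyl on the aminomethyl phenol series

The source may report more compounds than this note shows. Statements on the series, on what has been measured and on what is new or still open speak of the compounds shown alone.

Measured so far in an ADME assay on CHO cells (Cricetulus griseus) for inhibition, read by MTT assay; a higher number here means a weaker inhibitor, a lower number a stronger inhibitor:
compound 1 `CCNCc1cc(C)cc(Nc2nc3ccccc3n2Cc2ccc(C(F)(F)F)cc2)c1O` gives 18800 nM
compound 2 `CCNCc1cc(Cl)cc(Nc2nc3ccccc3n2Cc2ccc(C(F)(F)F)cc2)c1O` gives 33800 nM
compound 3 `Cc1cc(CNC(C)(C)C)c(O)c(Nc2nc3cc(F)c(F)cc3[nH]2)c1` gives 16700 nM

Compound 1 and compound 2 share one core; compound 3 carries a different core, and the difference between the two cores is not broken down here. Compound 1 and compound 3 sit close together in this assay, so no order between them is claimed.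

One change has been seen once: chloro in place of methyl on an aromatic carbon. Its step was a 1.8-fold higher number from compound 1 to compound 2 (0.25 log units; within the scatter).

The unmeasured compound 4 `CC(C)(C)NCc1cc(Cl)cc(Nc2nc3cc(F)c(F)cc3[nH]2)c1O` is reached from compound 3 by the same kind of change, (chloro in place of methyl on an aromatic carbon). The place differs in its surroundings: in compound 1 it is meta to a (ethylamino)methyl group, in compound 3 meta to a ((tert-butyl)amino)methyl group.

Among the compounds with values here, for compound 4 in this assay the expected step is a 1.8-fold higher number from compound 3 to compound 4 (0.25 log units; within the scatter), set beside the earlier one, because compound 2 moved by a 1.8-fold higher number from compound 1 to compound 2 (0.25 log units; within the scatter) on the same change; with only one prior example and a different core the expectation is loose. The estimate for compound 4 is 30000 nM, with a range from 12000 nM to 75000 nM.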

Compound 4, half-maximal inhibitory concentration: 39700 nM
Compound 4: middle estimate off by 1.3-fold (0.12 log units), on the low side; low and high end bracket the measured number.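

In this assay, chloro in place of methyl on an aromatic carbon gives a 2.4-fold higher number from compound 3 to compound 4 (0.38 log units; beyond the scatter), a modest rise in the number that points the same way as the step on the core of compound 1. The two cores therefore give no sign that this change behaves differently from one to the other, and the step carries across them with its direction and approximate size intact: the same change on two cores in this assay, a 1.8-fold higher number (0.25 log units; within the scatter) from compound 1 to compound 2 and a 2.4-fold higher number (0.38 log units; beyond the scatter) from compound 3 to compound 4, 1.3-fold (0.12 log units) apart, within the scatter of two such steps

This rests on just two pairs, only one of which clears the scatter, so it does not establish a general size for the step in this series or show that the ((tert-butyl)amino)methyl group and the other differences between the cores have no bearing on it.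

From the compounds shown here alone, whether bromo, methoxy or a nitrile in the same place would move the number as chloro does remains open. So does whether the step would hold with an (ethylamino)methyl group on the core of compound 3, or on a third core.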